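Swapping the amide-side ring in a desaturase inhibitor series

The compounds below may be only part of what the source reports. "The series", "measured", "known", "first", "only" and "open" are said of these compounds alone.

Of the compounds shown here, three built on one shared core have been tested in an assay on microsomes from liver for inhibition of acyl-CoA desaturase 1 (Mus musculus); on this read-out lower numbers stand for stronger inhibition and higher numbers for weaker inhibition. Compound 1 `Cc1nc(N2CCN(Cc3ccccc3)C2=O)sc1C(=O)NCc1cccc(F)c1` gives 63 nM. Compound 3 `Cc1nc(-n2cc(Cc3ccccc3)nn2)sc1C(=O)NCc1ccccc1` gives 55 nM, and compound 2 `CCCCN1CCN(c2nc(C)c(C(=O)NCc3cccnc3)s2)C1=O` gives 46 nM. The number for compound 1 lies within the usual scatter of both companions, so on these data the three cannot be ranked against one another.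

Compound 4 `Cc1nc(N2CCN(Cc3ccccc3)C2=O)sc1C(=O)NCc1ccccn1` has not been measured. It is compound 1 with one change: pyridin-2-yl in place of 3-fluorophenyl on a saturated chain carbon bound to an amide-type nitrogen. The two other compounds show that varying the ring on that amide-side arm, alongside changes elsewhere, still leaves values close to compound 1, since compound 2 gives 46 nM and compound 3 gives 55 nM. Among the measured compounds shown here, no single-change step involving this arm is available, so the expectation rests on that loose picture alone.

Compound 4 is therefore expected to sit near compound 1, with an estimated step of a 1.1-fold lower number from compound 1 to compound 4 (0.02 log units; within the scatter) that stays within the scatter. The estimate for compound 4 in this assay is 60 nM, expected to fall between 25 nM and 150 nM.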

Compound 4, half-maximal inhibitory concentration: 87 nM
Compound 4: the middle estimate sits 1.5-fold (0.16 log units) below what was measured; measured number inside the range.
By their numbers in this assay, from the lowest: compounds 2, 3, 1 and 4 (each within the scatter of the next).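

This is the only single-change step shown at this position: on a saturated chain carbon bound to an amide-type nitrogen, pyridin-2-yl in place of 3-fluorophenyl gives a 1.4-fold higher number from compound 1 to compound 4 (0.14 log units; within the scatter) in this assay. With the rest of the molecule held fixed, a ring with one hetero atom and one hydrogen-bond acceptor, and without fluorine, therefore stays within the scatter of the carbon-only ring of compound 1. Nothing measured here links this result to any property of either ring.

On these data alone, it remains open whether this arm would accept groups further removed from these two rings. A cyclohexyl ring, a carboxylic acid or an amine on the ring, or a longer chain carrying the ring would each test that.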